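The compounds below may be only part of what the source reports. "The series", "measured", "known", "first", "only" and "open" are said of these compounds alone.

Series notes. Compound 1 `CC(C)c1c(C(=O)N2CCCC2c2ccccc2)nn(-c2ccc(F)cc2)c1OC[C@@H](O)C[C@@H](O)CC(=O)O` and compound 2 `CC(C)c1c(C(=O)N2CCC[C@H](N3CCC4C=CC=CC4C3)C2)nn(-c2ccc(F)cc2)c1CC[C@@H](O)C[C@@H](O)CC(=O)O` share the core and the dihydroxy acid chain; in an assay on microsomes from liver for inhibition of 3-hydroxy-3-methylglutaryl-coenzyme A reductase (Rattus norvegicus) (a lower number here means a stronger inhibitor, a higher number a weaker inhibitor), compound 1 gives 14 nM, and compound 2 gives 10 nM. Compound 1 holds the higher of the two numbers, but the gap to compound 2 is within the scatter, so the two read the same for present purposes.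

Compound 3 `COc1ccc(CNC(=O)c2nn(-c3ccc(F)cc3)c(OC[C@@H](O)C[C@@H](O)CC(=O)O)c2C(C)C)cc1` is the next variant on compound 1: (4-methoxybenzyl)amino in place of 2-phenylpyrrolidin-1-yl on a carbonyl carbon. Within the data shown here, no measured pair isolates this change, so the expected step from compound 1 to compound 3 in this assay rests on compound 1 alone, with its value 14 nM as the anchor. A modest loss, at most slightly beyond the scatter, is expected: a 1.6-fold higher number from compound 1 to compound 3 (0.20 log units; within the scatter). On that basis compound 3 is estimated at 22 nM in this assay, with a range from 6 nM to 80 nM.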

Compound 3, half-maximal inhibitory concentration: 12 nM
The estimate for compound 3 lay 1.8-fold (0.26 log units) above the measured number, and the stated range covers the measured number.
By their numbers in this assay, from the lowest: compounds 2, 3 and 1 (each within the scatter of the next).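

On the carbonyl carbon of the shared core, (4-methoxybenzyl)amino in place of 2-phenylpyrrolidin-1-yl gives a 1.2-fold lower number from compound 1 to compound 3 (0.07 log units; within the scatter) in this assay, so the two compounds read the same. Among these compounds, this is the first measured pair at this position, and it shows that the five-membered non-aromatic ring can leave and the amide hydrogen can enter, with the number staying within the scatter in this one pair. No measurement shown bears on why the two compounds read the same.

This single pair cannot separate the contribution of the methoxy group from that of the amide hydrogen. Also open, going by these compounds, is whether plain benzylamino, or dimethylamino with no aromatic ring at all, on the same carbonyl carbon would read the same in this assay.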